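This account rests on a few compounds, and the source may have more. Where it says the series, first, only, none or still open, it means among the compounds named here.

Measured in an assay on microsomes from brain for inhibition of Fatty-acid amide hydrolase 1 (Rattus norvegicus), read by fluorescence and HPLC, with a stated time of 60 min; a higher number here means a weaker inhibitor, a lower number a stronger inhibitor:
compound 1 `CCCCCCCCc1ccc(OCC(=O)Cn2nnc(-c3cccc(C(=O)OC)c3)n2)cc1`, 34 nM
compound 2 `CCCCCCCCc1ccc(OCC(=O)Cn2nnc(-c3ccc(S(=O)(=O)N(C)C)cc3)n2)cc1`, 590 nM
compound 3 `CCCCCCCCc1ccc(OCC(=O)Cn2nnnc2-c2ccccc2)cc1`, 71 nM

All three share a long alkyl chain on a phenyl ether, joined through a ketone to a five-membered ring of four nitrogens that carries an aromatic ring. Compound 3 stands second highest of the three in this assay: its number is higher than that of compound 1 and lower than that of compound 2, and both gaps lie beyond the scatter.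

Compound 4 `CCCCCCCCc1ccc(OCC(=O)Cn2nnnc2-c2cccnc2)cc1` is compound 3 with one change: pyridin-3-yl in place of phenyl on an aromatic carbon. Among the measured compounds shown here, the only measured step in this set, a 17-fold higher number from compound 1 to compound 2 (1.24 log units; beyond the scatter), shows that altering the aromatic ring on the shared core can move the number a great deal, but that step changed groups attached to the ring, not a ring atom itself. For the measured compounds named here, no measured pair swaps a ring carbon for a ring nitrogen, so the direction here is uncertain, and a small change is expected, a 1.4-fold higher number from compound 3 to compound 4 (0.15 log units; within the scatter). Compound 4 is estimated at 100 nM, within 30 nM to 350 nM.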

Compound 4, half-maximal inhibitory concentration: 190 nM
The estimate for compound 4 lay 1.9-fold (0.28 log units) below the measured number; low and high end bracket the measured number.
By their numbers in this assay, from the lowest: compound 1; then compound 3; then compound 4; then compound 2.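

In this assay, putting pyridin-3-yl in place of phenyl on the aromatic carbon of the ring with four nitrogens gives a 2.7-fold higher number from compound 3 to compound 4 (0.43 log units; beyond the scatter), a modest but real weakening of inhibition. The earlier step changed only groups attached to the aromatic ring, whereas this pair shows that changing one atom of the ring itself also moves the number, with the count of heavy atoms unchanged and one hydrogen-bond acceptor added. Nothing measured here accounts for this rise.

The compounds shown leave open whether the ring nitrogen must sit exactly here, which pyridin-2-yl or pyridin-4-yl would help to settle. They also leave open how an amine or a carboxylic acid on the phenyl ring of compound 3 would change the number.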